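This account rests on a few compounds, and the source may have more. Where it says the series, first, only, none or still open, it means among the compounds named here.

Of the compounds shown here, three built on one shared core have been measured in a physicochemical assay for solubility, read by HPLC, with a stated time of 24 h; a lower number here means a less soluble compound, a higher number a more soluble compound. Compound 1 `O=C1O[C@@H](CN2CCC(O)CC2)CN1c1ccc(-n2cc(-c3ccccn3)cn2)c(F)c1` gives 45900 nM, compound 2 `O=C1O[C@@H](Cn2ccnc2)CN1c1ccc(-n2cc(-c3ccccn3)cn2)c(F)c1` gives 12300 nM, and compound 3 `CN(C)S(=O)(=O)NC[C@H]1CN(c2ccc(-n3cc(-c4ccccn4)cn3)c(F)c2)C(=O)O1` gives 472000 nM, the highest of the three. The steps of a 10-fold higher number from compound 1 to compound 3 (1.01 log units; beyond the scatter) and a 38-fold higher number from compound 2 to compound 3 (1.58 log units; beyond the scatter) both exchange the group on the same saturated chain carbon, and both moved the read-out a long way. Compound 4 `O=C(NC[C@H]1CN(c2ccc(-n3cc(-c4ccccn4)cn3)c(F)c2)C(=O)O1)C(F)F` differs from compound 3 by (difluoromethyl)carbonyl in place of dimethylsulfamoyl on an amine nitrogen. Within the data shown here, no measured compound carries an amide at that position, so the earlier swings set only the scale of what may happen, and a modest fall is expected, a 3.1-fold lower number from compound 3 to compound 4 (0.50 log units; beyond the scatter). Compound 4 is therefore estimated at 150000 nM, with a range from 50000 nM to 450000 nM.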

Compound 4, solubility: 29900 nM
Compound 4: middle estimate off by 5.0-fold (0.70 log units), on the high side; measured number outside the range, below it.
By their numbers in this assay, from the lowest: compound 2; then compounds 4 and 1 (each within the scatter of the next); then compound 3.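

In this assay, replacing dimethylsulfamoyl with (difluoromethyl)carbonyl on the amine nitrogen gives a 16-fold lower number from compound 3 to compound 4 (1.20 log units; beyond the scatter), so keeping that nitrogen on the chain carbon does not by itself hold the number up. Against the earlier groups, the new amide gives a 2.4-fold higher number from compound 2 to compound 4 (0.39 log units; beyond the scatter) and a 1.5-fold lower number from compound 1 to compound 4 (0.19 log units; within the scatter), which leaves compound 3 alone at the top. Nothing available explains the size of this fall.

The compounds shown leave open whether the sulfonyl part or the dimethylamino end of dimethylsulfamoyl matters. They also leave open whether an acetyl or a methanesulfonyl group on that nitrogen would stand nearer compound 3 or compound 4.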